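A few compounds are considered here, and "the series" means these few. Any claim that something is new, unique, unknown or untested is made for them only; others in the source may bear on it.

Compound 2 `Cc1cc(C(=O)O)nn1Cc1cc(Br)ccc1OCc1ccc(F)cc1` belongs to a small pair sharing one core; its companion is compound 1 `Cc1cc(C(=O)O)nn1Cc1cc(Br)ccc1OCc1ccc(F)cc1F`. In an assay on CHO-K1 cells for displacement of a labelled ligand from prostaglandin E2 receptor EP1 subtype (Homo sapiens) (a higher number here means a weaker inhibitor, a lower number a stronger inhibitor), compound 1 gives 0.525 nM, while in this assay compound 2 gives 7.41 nM, the higher of the two numbers. Among the compounds with values here, the only step recorded between them, a 14-fold higher number from compound 1 to compound 2 (1.15 log units; beyond the scatter), is a hydrogen in place of fluoro on an aromatic carbon of the benzyl ether ring. Compound 3 `Cc1cccc(COc2ccc(Br)cc2Cn2nc(C(=O)O)cc2C)c1` is not yet measured; it differs from compound 2 by 3-methylphenyl in place of 4-fluorophenyl on a saturated chain carbon bound to an oxygen on an aromatic ring. Within the data shown here, no measured step concerns this exchange itself; the step from compound 1 to compound 2 only shows that the substitution of this ring can move the number a great deal. Without a closer precedent, compound 3 is expected to lie near compound 2, with a wide range, an estimated step of a 1.6-fold higher number from compound 2 to compound 3 (0.21 log units; within the scatter). The estimate for compound 3 in this assay is 12 nM, between 3 nM and 50 nM.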

Compound 3, half-maximal inhibitory concentration: 126 nM
Compound 3: the middle estimate sits 11-fold (1.02 log units) below what was measured, and the stated range ends below it.
By their numbers in this assay, from the lowest: compound 1; then compound 2; then compound 3.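

In this assay, the ring on the saturated chain carbon bound to an oxygen on an aromatic ring proves sensitive to more than the loss of a fluoro: 3-methylphenyl in place of 4-fluorophenyl gives a 17-fold higher number from compound 2 to compound 3 (1.23 log units; beyond the scatter). Taken from the difluorinated ring, the exchange gives a 240-fold higher number from compound 1 to compound 3 (2.38 log units; beyond the scatter), which makes compound 3 the weakest of the three and shows that this one place can span a very wide range while the rest of the structure stays the same. Within the data shown here, nothing available explains why this exchange moves the number so far.

This exchange removes the fluoro and adds the methyl at once, so the share of each in the step remains unresolved. An unsubstituted phenyl or a 4-methylphenyl at this place would be needed to separate them.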